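The source may hold more compounds than are shown below. What is called first, only, known or untested is meant among the compounds shown, and "the series" means these compounds.

In an assay on cells for inhibition of ileal sodium/bile acid cotransporter (Homo sapiens) (a higher number here means a weaker inhibitor, a lower number a stronger inhibitor), the measured compounds stand as follows: compound 1 `CCCC[C@]1(CC)CS(=O)(=O)c2ccc(N)cc2[C@@H](c2ccccc2)[C@H]1O` gives 68 nM; compound 2 `CCCC[C@]1(CC)CS(=O)(=O)c2ccc(NC(=O)OCc3ccccc3)cc2[C@@H](c2ccccc2)[C@H]1O` gives 400 nM; compound 3 `CCCCCCNc1ccc2c(c1)[C@@H](c1ccccc1)[C@@H](O)[C@](CC)(CCCC)CS2(=O)=O` gives 1670 nM.

Compound 3 thus has the highest number of the three, with a 4.2-fold higher number from compound 2 to compound 3 (0.62 log units; beyond the scatter) and a 25-fold higher number from compound 1 to compound 3 (1.39 log units; beyond the scatter). Compound 4 `CCCC[C@]1(CC)CS(=O)(=O)c2ccc(N(C)C)cc2[C@@H](c2ccccc2)[C@H]1O` differs from compound 3 by dimethylamino in place of hexylamino on an aromatic carbon. Within the data shown here, the steps that bear on this are a 25-fold higher number from compound 1 to compound 3 (1.39 log units; beyond the scatter) and a 5.9-fold higher number from compound 1 to compound 2 (0.77 log units; beyond the scatter), both showing that any substituent on this nitrogen raised the number relative to compound 1, the larger one more so. Since the dimethylamino group is smaller than hexylamino but still no longer a donor, compound 4 is expected to land between compounds 1 and 3, a modest drop a 4.8-fold lower number from compound 3 to compound 4 (0.68 log units; beyond the scatter). The estimate for compound 4 in this assay is 350 nM, within 120 nM to 1100 nM.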

Compound 4, half-maximal inhibitory concentration: 5 nM
Compound 4: the middle estimate sits 70-fold (1.85 log units) above what was measured; measured number below the stated range.
By their numbers in this assay, from the lowest: compound 4; then compound 1; then compound 2; then compound 3.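

In this assay, a substituent on this nitrogen does not always raise the number: dimethylamino in place of amino goes the other way (a 14-fold lower number from compound 1 to compound 4 (1.13 log units; beyond the scatter)), unlike the hexyl and benzyloxycarbonyl groups. The choice of group at this aromatic carbon therefore spans a wide range (a 330-fold lower number from compound 3 to compound 4 (2.52 log units; beyond the scatter); an 80-fold lower number from compound 2 to compound 4 (1.90 log units; beyond the scatter)), and size alone does not settle the order, since amino is the smallest group yet compound 4 has the lowest number. Nothing measured here accounts for this result.

As far as these compounds go, whether methylamino or diethylamino would stand closer to compound 4 or to compound 3 remains open. So does whether a chain such as hexyl would be tolerated on a nitrogen that also carries a methyl group.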